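Swapping the fluorophenyl on the acyl urea

The source may report more compounds than this note shows. Statements on the series, on what has been measured and on what is new or still open speak of the compounds shown alone.

Measured so far:
- compound 1 `CN(C(=O)NC(=O)c1ccc(F)c(F)c1)c1nc(C(F)(F)F)c(C(=O)N/N=C/c2ccc(C(F)(F)F)cc2)s1`: 6.07 ug/mL
- compound 2 `CN(C(=O)NC(=O)c1ccc(F)c(F)c1)c1nc(C(F)(F)F)c(C(=O)N/N=C/c2cccc(C(F)(F)F)c2)s1`: 6.52 ug/mL

Both compounds were tested in a functional assay on A549 cells (Homo sapiens) for inhibition, read by MTT assay, with a stated time of 72 h; on this read-out higher numbers stand for weaker inhibition and lower numbers for stronger inhibition. For the measured compounds named here, compound 1 holds the lowest of the two numbers, but its only neighbour is compound 2, and the move a 1.1-fold higher number from compound 1 to compound 2 (0.03 log units; within the scatter) shows that the two values cannot be told apart. That single measured step concerns the trifluoromethylphenyl group on the carbon with a double bond to nitrogen, at the far end of the shared core.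

Compound 3 `CN(C(=O)NC(=O)c1ccccc1F)c1nc(C(F)(F)F)c(C(=O)N/N=C/c2ccc(C(F)(F)F)cc2)s1` changes a different place. Compared with compound 1, the difference is 2-fluorophenyl in place of 3,4-difluorophenyl on a carbonyl carbon. Going by the values given here, no measured step touches this carbonyl carbon or the ring attached to it, so nothing in the data says how the number should move. Among the compounds with values here, the one step that exists lies within the scatter and concerns another part of the molecule, so it offers no direction either. The reasonable expectation for compound 3 is therefore a value close to compound 1, with the step of a 1.1-fold higher number from compound 1 to compound 3 (0.03 log units; within the scatter) expected to stay within the scatter. The estimate for compound 3 is 6.5 ug/mL, with a range from 3 ug/mL to 14 ug/mL.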

Compound 3, half-maximal inhibitory concentration: 5.68 ug/mL
For compound 3 the middle estimate is 1.1-fold (0.06 log units) above the measured one; low and high end bracket the measured number.
By their numbers in this assay, from the lowest: compounds 3, 1 and 2 (each within the scatter of the next).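

In this assay, for the compounds shown here, the step of a 1.1-fold lower number from compound 1 to compound 3 (0.03 log units; within the scatter) gives the first measured reading for the ring on the carbonyl carbon, and 2-fluorophenyl and 3,4-difluorophenyl cannot be told apart there. The earlier step spoke only for the trifluoromethylphenyl group, so the data now cover two places in the molecule, and at both the pair of values stays within the scatter. The swap at this new place is a small one, with 7 heavy atoms and 1 fluorine entering for 8 heavy atoms and 2 fluorines, and the data offer no measured property that could account for the result.

On these data alone, both groups compared here are fluorinated phenyl rings, so it remains open whether this position would tolerate a plain phenyl group, an aminophenyl group or a phenyl ring carrying a carboxylic acid as readily, or whether a larger departure would shift the number beyond the scatter. As far as these compounds go, it also remains open whether the same tolerance would hold with the 3-(trifluoromethyl)phenyl group in place of the 4-(trifluoromethyl)phenyl group, since each step here covers only one place.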